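A few compounds are considered here, and "the series" means these few. Any claim that something is new, unique, unknown or untested is made for them only; others in the source may bear on it.

Working notes on the series.

The shared core is fixed; the variation lies in the substituent carried on the oxazole-side arm. Compound 1 `O=C(CCCCCCc1ccccc1)c1ncc(-c2ccc(CCl)cn2)o1` gives 24.6 nM in an assay for inhibition of Fatty-acid amide hydrolase 1 (Rattus norvegicus), using a Dixon plot, with a stated time of 6 h; on this read-out higher numbers stand for weaker inhibition and lower numbers for stronger inhibition. Compound 2 `CCOS(=O)(=O)/C=C/c1ccc(-c2cnc(C(=O)CCCCCCc3ccccc3)o2)nc1` gives 0.2 nM in this assay, and compound 3 `CSC(=O)CCCCc1cnc(C(=O)CCCCCCc2ccccc2)o1` gives 1.5 nM. Among the three numbers compound 3 stands second highest: compound 2 sits a good way lower, beyond the scatter, and compound 1 further off on the high side, also beyond the scatter.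

The two measured steps both start from compound 1. Replacing the chloromethyl on the aromatic carbon by the 2-(ethoxysulfonyl)ethenyl gave a 120-fold lower number from compound 1 to compound 2 (2.09 log units; beyond the scatter); exchanging the whole ring-bearing group for the open chain of compound 3 gave a 16-fold lower number from compound 1 to compound 3 (1.21 log units; beyond the scatter). Both steps show that the terminus of this arm moves the number by a large margin.

Compound 4 `N#CCCCCCc1cnc(C(=O)CCCCCCc2ccccc2)o1` differs from compound 3 by cyanomethyl in place of (methylsulfanyl)carbonyl on a saturated chain carbon, four bonds along the chain from an aromatic carbon. Going by the values given here, no measured step covers this exact exchange; the terminus of the arm has changed a lot in every measured step, so a shift beyond the scatter is expected here too, most likely toward a higher number. The estimate for compound 4 in this assay is 12 nM, within 2 nM to 80 nM, which corresponds to an expected step of an 8.0-fold higher number from compound 3 to compound 4 (0.90 log units; beyond the scatter).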

Compound 4, inhibition constant: 4 nM
For compound 4 the middle estimate is 3.0-fold (0.48 log units) above the measured one, within the range that was stated.
By their numbers in this assay, from the lowest: compound 2; then compound 3; then compound 4; then compound 1.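

In this assay the exchange of (methylsulfanyl)carbonyl for cyanomethyl on a saturated chain carbon, four bonds along the chain from an aromatic carbon, gives a 2.7-fold higher number from compound 3 to compound 4 (0.43 log units; beyond the scatter) and is graded modest, whereas both steps measured earlier were graded large. The low number of compound 3 is therefore not tied to the (methylsulfanyl)carbonyl end alone, since the open chain ending in a nitrile still gives a 6.2-fold lower number from compound 1 to compound 4 (0.79 log units; beyond the scatter) and so also stands on the low side of compound 1. The compounds shown offer no independent measurement that would account for the difference between these two chain ends.

Going by these compounds, it remains open whether the chain end needs either of these groups at all, which a carboxylic acid, a primary amide, an amine or a plain unsubstituted alkyl end on the same chain would help to settle. On these data alone, it is also open how the number depends on chain length, which a shorter or longer chain ending in the same nitrile would address.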